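This account rests on a few compounds, and the source may have more. Where it says the series, first, only, none or still open, it means among the compounds named here.

Measured so far in an ADME assay on NIH3T3 cells (Mus musculus) for cytotoxicity, read by MTT assay, with a stated time of 24 h; a higher number here means a weaker inhibitor, a lower number a stronger inhibitor:
Compound 1, `CN(C)CCN1CCN(CC(=O)Nc2ccc(-c3nc4cc(F)ccc4o3)cc2)CC1`, gives 72000 nM.
Compound 2, `Cc1cc(-c2nc3cc(F)ccc3o2)ccc1NC(=O)CN1CCN(CCN(C)C)CC1`, gives 62100 nM.
Compound 3, `Cc1ccc2oc(-c3ccc(NC(=O)CN4CCN(CCCN(C)C)CC4)cc3)nc2c1`, gives 26400 nM.

Compound 3 has the lowest of these three numbers, so it is the strongest inhibitor of the three in this assay; compound 2 comes nearest and compound 1 furthest, and both of those gaps lie beyond the scatter. Compound 3 differs from compound 1 and from compound 2 in more than one place, so those values can only be set side by side, not read as single steps.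

Compound 4, `Cc1ccc2oc(-c3ccc(NC(=O)CN4CCN(CCCN(C)C)CC4)c(C)c3)nc2c1`, has not yet been measured. It arises from compound 3 by a single change: methyl in place of hydrogen on an aromatic carbon. For the measured compounds named here, one measured step bears on this change, namely a 1.2-fold lower number from compound 1 to compound 2 (0.06 log units; within the scatter), which was the same kind of change, methyl in place of hydrogen on an aromatic carbon, in another pair of compounds. That step did not move the number beyond the scatter. For compound 4 the same behaviour is expected: a small step in this assay, a 1.1-fold lower number from compound 3 to compound 4 (0.06 log units; within the scatter), not beyond the scatter, leaning if anything toward a slightly lower number. Compound 4 is therefore estimated at 23000 nM, with a range from 9000 nM to 60000 nM.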

Compound 4, half-maximal inhibitory concentration: 13200 nM
For compound 4 the middle estimate is 1.7-fold (0.24 log units) above the measured one; the measured number falls inside the stated range.
By their numbers in this assay, from the lowest: compounds 4 and 3 (each within the scatter of the next); then compounds 2 and 1 (each within the scatter of the next).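

In this assay, the methyl on the aromatic carbon ortho to a large group and meta to a 5-methyl-1,3-benzoxazol-2-yl group gives a 2.0-fold lower number from compound 3 to compound 4 (0.30 log units; within the scatter). Before this result, the change had been seen in a single pair of compounds; it has now been seen on a second core, and in neither pair does the step go beyond the usual scatter of repeated measurements. The two pairs therefore agree that, on these two cores, putting methyl in place of hydrogen at this position gives no step that can be told apart from that scatter, and the size of the step is consistent from one core to the other: the same change on two cores in this assay, a 1.2-fold lower number (0.06 log units; within the scatter) from compound 1 to compound 2 and a 2.0-fold lower number (0.30 log units; within the scatter) from compound 3 to compound 4, 1.7-fold (0.24 log units) apart, within the scatter of two such steps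

The compounds shown carry only hydrogen or methyl at this position, so it remains open whether a different group there, such as chlorine, methoxy or a longer chain like ethyl, would move the number beyond the scatter. From the compounds shown here alone, it also remains open whether the methyl would behave the same way on a core where a morpholine ring replaces the piperazine ring and its amine side chain.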